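Series notes: removing the tosyl group from the aryl oxygen

The source may report more compounds than this note shows. Statements on the series, on what has been measured and on what is new or still open speak of the compounds shown alone.

Compound 1 `C=C1C[C@]23C[C@@]1(O)CC[C@H]2c1ccc(OS(=O)(=O)c2ccc(C)cc2)c(C)c1[C@@H]3Cn1cc(-c2ccc(OC)cc2)nn1` is known in a functional assay on A549 cells (Homo sapiens) for cytotoxicity, read by MTT assay, with a stated time of 4 days (a lower number here means a stronger inhibitor, a higher number a weaker inhibitor), only as a limit of the assay: compound 1 gives > 20000 nM. Compound 2 `C=C1C[C@]23C[C@@]1(O)CC[C@H]2c1ccc(OS(=O)(=O)c2ccc(C)cc2)c(C)c1[C@@H]3Cn1cc(-c2ccc(C)cc2)nn1` likewise returns a limit; in this assay compound 2 gives > 20000 nM. The step that the two limits leave unreadable from compound 1 to compound 2 cannot be read because of the limit of > 20000 nM in this assay, at which 2 of the 2 values shown sit. Compound 3 `C=C1C[C@]23C[C@@]1(O)CC[C@H]2c1ccc(O)c(C)c1[C@@H]3Cn1cc(-c2ccc(OC)cc2)nn1` differs from compound 1 by hydrogen in place of (4-methylphenyl)sulfonyl on an oxygen on an aromatic ring. For the measured compounds named here, no measured step bears on this change, and the two values known give no direction for it. The expected step of a number no higher from compound 1 to compound 3 (the limit leaves the size open) is therefore set with no readable direction. Compound 3 is estimated at 20000 nM, with a range from 3000 nM to 60000 nM.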

Compound 3, half-maximal inhibitory concentration: > 20000 nM
Compound 3: no number, only a limit (the forecaster's own chance of this, stated with the estimate: 55%); the middle value lies on the limit itself.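

Compound 3 also returns only a limit, so no step from compound 1 to compound 3 can be read: the limit of > 20000 nM in this assay, at which 3 of the 3 values shown sit.

The compounds shown leave open whether hydrogen in place of (4-methylphenyl)sulfonyl on this oxygen changes the read-out at all.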